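Nitrophenyl Amide Replaces Thiophene in Pancreatic Cell Series

The compounds below may be only part of what the source reports. "The series", "measured", "known", "first", "only" and "open" are said of these compounds alone.

Within the data shown here, compound 3 `CC(C)=CCC1Cc2c(OCCCNC(=O)c3cccs3)cc(=O)n(CCCO)c2CC1(C)C` stands second highest of the three numbers known in a functional assay on PANC-1 cells (Homo sapiens) for inhibition, read by MTT assay, with a stated time of 24 h, tested at 10 uM (on this read-out higher numbers stand for more inhibition at the one concentration tested (going by the name of the read-out) and lower numbers for less inhibition), where compound 3 gives 33.6%; compound 1 `CC(C)=CCC1Cc2c(OCCCNS(=O)(=O)c3ccc(Br)cc3)cc(=O)n(CCCO)c2CC1(C)C` gives 19.5%, and compound 2 `CC(C)=CCC1Cc2c(OCCCNS(=O)(=O)c3ccc([N+](=O)[O-])cc3)cc(=O)n(CCCO)c2CC1(C)C` gives 47.7%. Compound 4 `CC(C)=CCC1Cc2c(OCCCNC(=O)c3ccc([N+](=O)[O-])cc3)cc(=O)n(CCCO)c2CC1(C)C` differs from compound 3 by 4-nitrophenyl in place of thiophen-2-yl on a carbonyl carbon. Among the measured compounds shown here, two measured steps bear on this change: a number 28.2 percentage points higher from compound 1 to compound 2 (beyond the scatter), and a number 14.1 percentage points lower from compound 2 to compound 3 (beyond the scatter), while a number 14.1 percentage points higher from compound 1 to compound 3 (beyond the scatter). For the measured compounds named here, because compound 2 gives 47.7% with the 4-nitrophenyl group, a modest rise in this assay is expected for compound 4, with a number 11.4 percentage points higher from compound 3 to compound 4 (beyond the scatter), though the swap of sulfonyl for carbonyl has no direct precedent here. Compound 4 is therefore estimated at 45%, between 28% and 62%.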

Compound 4, a percentage reported as inhibition, at one concentration (the size of the read-out at that concentration, not a potency): 49.9%
Estimate against measurement, compound 4: 4.9 percentage points below; the range from low to high includes it.
By their numbers in this assay, from the lowest: compound 1; then compound 3; then compounds 2 and 4 (each within the scatter of the next).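

In this assay, the number is higher with 4-nitrophenyl than with thiophen-2-yl on the carbonyl carbon, with a number 16.3 percentage points higher from compound 3 to compound 4 (beyond the scatter). With the 4-nitrophenyl group kept, the carbonyl and sulfonyl forms cannot be told apart, at a number 2.2 percentage points higher from compound 2 to compound 4 (within the scatter), while the large step, a number 30.4 percentage points higher from compound 1 to compound 4 (beyond the scatter), combines the change of linking group with nitro in place of bromo. Nothing available explains these differences. As far as these compounds go, whether an amine or a nitrile in place of the nitro group would preserve this level of inhibition stays open, as does the outcome of a longer chain carrying the amide.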